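Ether side-chain variation on a shared core

The compounds below may be only part of what the source reports. "The series", "measured", "known", "first", "only" and "open" are said of these compounds alone.

Compound 1 `CCCCOCCOC1CCN(c2nc(N)c3cc(OC)c(OC)cc3n2)CC1`: 1.03 nM
Compound 2 `COc1cc2nc(N3CCC(OCCO)CC3)nc(N)c2cc1OC`: 2.2 nM
Compound 3 `COc1cc2nc(N3CCC(OCC(C)(C)OC)CC3)nc(N)c2cc1OC`: 1.14 nM

Of the compounds shown here, three have been measured in an assay on brain for displacement of a labelled ligand from Adrenergic receptor alpha-1 (Rattus norvegicus); a higher number here means a weaker inhibitor, a lower number a stronger inhibitor. Compound 3 stands second highest of the three numbers, and the steps of a 1.1-fold higher number from compound 1 to compound 3 (0.04 log units; within the scatter) and a 1.9-fold lower number from compound 2 to compound 3 (0.29 log units; within the scatter) both lie within the scatter. Compound 4 `CCOC(COC1CCN(c2nc(N)c3cc(OC)c(OC)cc3n2)CC1)c1ccccc1` differs from compound 3 by ethoxy(phenyl)methyl in place of 1-methoxy-1-methylethyl on a saturated chain carbon bound to an oxygen on a saturated carbon. Within the data shown here, the earlier changes at this same place, the two steps into compound 3, left the number essentially where it was; the only step beyond the scatter, a 2.1-fold higher number from compound 1 to compound 2 (0.33 log units; beyond the scatter), concerns a different change, hydrogen in place of butyl on an oxygen. The step from compound 3 to compound 4 is therefore expected to stay within the scatter, a 1.1-fold higher number from compound 3 to compound 4 (0.02 log units; within the scatter). Compound 4 is expected to give 1.2 nM in this assay, between 0.5 nM and 3 nM.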

Compound 4, inhibition constant: 0.52 nM
For compound 4 the middle estimate is 2.3-fold (0.36 log units) above the measured one; low and high end bracket the measured number.
By their numbers in this assay, from the lowest: compounds 4, 1, 3 and 2 (each within the scatter of the next, the first and the last beyond it).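

In this assay, among these compounds, ethoxy(phenyl)methyl, which brings a six-membered aromatic ring, gives the first changes beyond the scatter among the replacements at this place (a 2.2-fold lower number from compound 3 to compound 4 (0.34 log units; beyond the scatter); a 4.2-fold lower number from compound 2 to compound 4 (0.63 log units; beyond the scatter)). Against butoxymethyl the same group stays within the scatter (a 2.0-fold lower number from compound 1 to compound 4 (0.30 log units; within the scatter)), so this place accepts the larger group with no loss in the number. No evidence is at hand on what lies behind these steps. The compounds shown leave open whether the aromatic ring or the ethoxy group carries the step, and how an amine or a carboxylic acid at this place would read.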